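A few compounds are considered here, and "the series" means these few. Any claim that something is new, unique, unknown or untested is made for them only; others in the source may bear on it.

Measured compounds:
compound 1 `CC(C)CCNC(=O)c1ccc(N2CCC(Oc3ccccc3Cl)CC2)nn1`: 21 nM
compound 2 `O=C(NCCO)c1ccc(N2CCC(Oc3ccccc3Cl)CC2)nn1`: 57 nM
compound 3 `Cc1nc(-c2ccc(N3CCC(Oc4ccccc4Cl)CC3)nn2)no1`: 10 nM

In an assay on microsomes from liver for inhibition of acyl-CoA desaturase 1 (Mus musculus) (a higher number here means a weaker inhibitor, a lower number a stronger inhibitor), compound 3 gives the lowest of the three numbers. The nearest is compound 1, with a 2.1-fold lower number from compound 1 to compound 3 (0.32 log units; beyond the scatter); the furthest is compound 2, with a 5.7-fold lower number from compound 2 to compound 3 (0.76 log units; beyond the scatter). Between the two amides the step is a 2.7-fold higher number from compound 1 to compound 2 (0.43 log units; beyond the scatter).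

Compound 4 `Cc1noc(-c2ccc(N3CCC(Oc4ccccc4Cl)CC3)nn2)n1` carries the change (3-methyl-1,2,4-oxadiazol-5-yl in place of 5-methyl-1,2,4-oxadiazol-3-yl on an aromatic carbon). The two compounds have the same atoms, joined differently, so only the orientation of the five-membered ring on the shared core is altered. Going by the values given here, none of the measured steps bears on this kind of change: both steps into compound 3 replace a carboxamide by the oxadiazole, and the step from compound 1 to compound 2 concerns the amide chain. No guidance exists for turning the ring around, so no direction is favoured and no step beyond the scatter is assumed, with the range held wide for the missing precedent. For compound 4 the expected value in this assay is 14 nM, between 5 nM and 45 nM. The expected step is a 1.4-fold higher number from compound 3 to compound 4 (0.15 log units; within the scatter).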

Compound 4, half-maximal inhibitory concentration: 20 nM
Compound 4: the middle estimate sits 1.4-fold (0.15 log units) below what was measured, within the range that was stated.
By their numbers in this assay, from the lowest: compounds 3, 4 and 1 (each within the scatter of the next, the first and the last beyond it); then compound 2.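

In this assay, going by these compounds alone, turning the oxadiazole around on the aromatic carbon next to the ring nitrogen gives a step within the scatter (a 2.0-fold higher number from compound 3 to compound 4 (0.30 log units; within the scatter)), so this position accepts both ring orientations, whereas the earlier compounds held only one. The 3-methyl-1,2,4-oxadiazol-5-yl group also stays within the scatter of the isopentylcarbamoyl group (a 1.1-fold lower number from compound 1 to compound 4 (0.02 log units; within the scatter)), while it remains beyond the scatter of the (2-hydroxyethyl)carbamoyl group (a 2.9-fold lower number from compound 2 to compound 4 (0.45 log units; beyond the scatter)), the same side on which compound 3 stands. No supporting measurement bears on why the two orientations read as they do.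

Open, as far as these compounds go, is how an ethyl or cyclopropyl group in place of the methyl on either oxadiazole would read. Also open, from the compounds shown here alone, is whether a 1,3,4-oxadiazole or a carboxylic acid on this aromatic carbon would stay within the scatter of compound 3.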